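Series notes: aryl carbonyl change on the hydroxamic acid core

The source may report more compounds than this note shows. Statements on the series, on what has been measured and on what is new or still open speak of the compounds shown alone.

For the measured compounds named here, compound 2, `Cc1cc(C)cc(C(=O)N(CCC(=O)NCc2ccccc2)Cc2ccc(C(=O)NO)cc2)c1`, stands highest of the two numbers so far in a functional assay on NB1 cells (Homo sapiens) for antiproliferative activity, with a stated time of 72 h (a higher number here means a weaker inhibitor, a lower number a stronger inhibitor), where compound 2 gives 3870 nM. Going by the values given here, compound 1, `Cc1ccc(NC(=O)CCN(Cc2ccc(C(=O)NO)cc2)C(=O)c2ccc(N(C)C)cc2)cc1`, gives 660 nM in this assay; the gap between these two is beyond the scatter, but the two structures differ in more than one place and no single step between them can be read. Compound 3, `CN(C)c1ccc(C(=O)N(CCC(=O)NCc2ccccc2)Cc2ccc(C(=O)NO)cc2)cc1`, arises from compound 2 by 4-(dimethylamino)phenyl in place of 3,5-dimethylphenyl on a carbonyl carbon. The step from compound 2 to compound 3 is expected to lower the number, a 3.2-fold lower number from compound 2 to compound 3 (0.51 log units; beyond the scatter), because compound 1 carrying the same aryl gives 660 nM. Compound 3 is estimated at 1200 nM, with a range from 450 nM to 3200 nM.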

Compound 3, half-maximal inhibitory concentration: 1720 nM
The estimate for compound 3 lay 1.4-fold (0.16 log units) below the measured number, and the stated range covers the measured number.
By their numbers in this assay, from the lowest: compound 1; then compound 3; then compound 2.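

In this assay the carbonyl change can now be read alone, with a 2.3-fold lower number from compound 2 to compound 3 (0.35 log units; beyond the scatter) when 4-(dimethylamino)phenyl replaces 3,5-dimethylphenyl and the benzyl amide is held fixed. With that aryl held fixed, the amide-type nitrogen also becomes readable, with a 2.6-fold higher number from compound 1 to compound 3 (0.42 log units; beyond the scatter) for benzyl in place of 4-methylphenyl, so both places move the number modestly. No data bearing on the origin of either step are available.

Open, going by these compounds, is whether morpholine in place of the dimethylamino group would keep the lower number, and whether a phenethyl group on the amide-type nitrogen would follow benzyl or 4-methylphenyl.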